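The compounds below may be only part of what the source reports. "The series", "measured", "known", "first", "only" and "open" are said of these compounds alone.

Two members of the series carry numbers in an assay on isolated protein for inhibition of Thymidylate synthase (Homo sapiens); on this read-out lower numbers stand for stronger inhibition and higher numbers for weaker inhibition. Compound 1 `Cc1ccc(-c2csc(=N)n2CC(=O)N2CCN(c3ccccc3)CC2)cc1` gives 5600 nM, and compound 2 `N=c1scc(-c2ccccc2)n1CC(=O)N1CCOCC1` gives 6220 nM. Compound 1 holds the lower of the two numbers, but its gap to compound 2 lies within the scatter, so the two cannot be told apart on this read-out. Going by the values given here, no step between measured compounds that differ in one place is available, so no measured step guides the next change.

Compound 3 `Cc1ccc(-c2csc(=N)n2CC(=O)N2CCN(C)CC2)cc1` has not been measured in this assay. It differs from compound 1 by methyl in place of phenyl on an amine nitrogen in a ring. With no measured step of this kind in the series, the expectation rests on compound 1 at 5600 nM alone; a move toward a somewhat higher number is expected, though one that may well stay within the scatter. The step from compound 1 to compound 3 is expected to be a 1.6-fold higher number from compound 1 to compound 3 (0.21 log units; within the scatter). For compound 3 the estimate in this assay is 9000 nM, within a range of 3000 nM to 30000 nM.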

Compound 3, inhibition constant: 19300 nM
Compound 3: the middle estimate sits 2.1-fold (0.33 log units) below what was measured; measured number inside the range.
By their numbers in this assay, from the lowest: compounds 1 and 2 (each within the scatter of the next); then compound 3.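

In this assay, the group on the amine nitrogen in the six-membered ring now has a measured step: methyl in place of phenyl gives a 3.4-fold higher number from compound 1 to compound 3 (0.54 log units; beyond the scatter). Going by these compounds alone, this is the first step that lies beyond the scatter, so the number is not indifferent to the group at this position, and phenyl goes with the lower number in this pair, though the step is modest and rests on a single pair of compounds. Nothing measured here accounts for the step.

Going by these compounds, with only phenyl and methyl compared on this nitrogen, it remains open whether the number follows the heavy-atom count of the group or the presence of a ring, and a cyclohexyl ring, a benzyl group or a longer alkyl chain at the same place would help separate these two readings. Also open, on these data alone, is whether a phenyl ring bearing fluorine or a methoxy group, or a pyridine ring in its place, would move the number away from that of compound 1 at 5600 nM by more than the scatter.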